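Moving the Fluorine on the Aniline Ring

The source may report more compounds than this note shows. Statements on the series, on what has been measured and on what is new or still open speak of the compounds shown alone.

The series shares one core. Compound 1 `Fc1cccc(-c2nc(Nc3ccccc3)c3cc(F)ccc3n2)c1` carries an unsubstituted phenyl on the ring nitrogen and gives 47600 nM in a functional assay on U2OS cells (Homo sapiens) for cytotoxicity, read by MTT assay, with a stated time of 48 h; a higher number here means a weaker inhibitor, a lower number a stronger inhibitor. Compound 2 `COc1ccccc1Nc1nc(-c2cccc(F)c2)nc2ccc(F)cc12` reaches only the limit of the assay, > 50000 nM. Compound 3 `Fc1ccc(Nc2nc(-c3cccc(F)c3)nc3ccc(F)cc23)cc1` likewise reaches only the limit, > 50000 nM. The step of an at least 1.0-fold higher number from compound 1 to compound 2 (0.02 log units; that floor lies within the scatter) and the step of an at least 1.0-fold higher number from compound 1 to compound 3 (0.02 log units; that floor lies within the scatter) both run toward that limit, and the step that the two limits leave unreadable from compound 2 to compound 3 cannot be sized at all, as the limit of > 50000 nM in this assay, at which 2 of the 3 values shown sit, shows. Compound 3 thus stands at the limit, and no number is known for it.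

Compound 4 `Fc1cccc(Nc2nc(-c3cccc(F)c3)nc3ccc(F)cc23)c1` differs from compound 3 by 3-fluorophenyl in place of 4-fluorophenyl on a nitrogen on an aromatic ring. The two steps that reach compound 2 and compound 3 leave no room for reading how this change acts, so no direction beyond the scatter is expected. Compound 4 is therefore estimated at 50000 nM, between 20000 nM and 150000 nM. That estimate amounts to an expected step of a number no higher from compound 3 to compound 4 (the limit leaves the size open).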

Compound 4, half-maximal inhibitory concentration: 49600 nM
Beside the measured number, compound 4's estimate is 1.0-fold (0.00 log units) above it; measured number inside the range.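

For the compounds shown here, compound 4 gives the first number for a fluoro on the phenyl carried by the ring nitrogen, where compound 2 and compound 3 gave only limits. In this assay the change from hydrogen to fluoro, here as the 3-fluorophenyl group, gives a 1.0-fold higher number from compound 1 to compound 4 (0.02 log units; within the scatter) and so compound 1 and compound 4 cannot be told apart. The steps of a number no higher from compound 2 to compound 4 (the limit leaves the size open) and a number no higher from compound 3 to compound 4 (the limit leaves the size open) cannot be read, because one side of each is only a limit of the assay: the limit of > 50000 nM in this assay, at which 2 of the 4 values shown sit.

Going by these compounds, whether the 3-fluorophenyl and 4-fluorophenyl groups differ at all in this assay remains open.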